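Nucleoside urea series: removing the phenylcarbamoyl group

This account rests on a few compounds, and the source may have more. Where it says the series, first, only, none or still open, it means among the compounds named here.

Compound 1 `CNC(=O)NC[C@H]1O[C@@H](n2cnc3c(NC(=O)Nc4ccccc4)ncnc32)[C@H](O[Si](c2ccccc2)(c2ccccc2)C(C)(C)C)[C@@H]1O[Si](c1ccccc1)(c1ccccc1)C(C)(C)C` carries silyl ethers on the sugar and in a functional assay on HeLa cells (Homo sapiens) for antiproliferative activity, with a stated time of 96 h (on this read-out higher numbers stand for weaker inhibition and lower numbers for stronger inhibition), compound 1 gives 104 ug/mL. Compound 2 `CNC(=O)NC[C@H]1O[C@@H](n2cnc3c(NC(=O)Nc4ccccc4)ncnc32)[C@H](OC(=O)c2ccccc2)[C@@H]1OC(=O)c1ccccc1` has benzoate esters in place of the silyl ethers. In this assay compound 2 reaches only the limit of the measurement, > 200 ug/mL, so no number is known for it; it stands at the limit of > 200 ug/mL in this assay, at which 1 of the 2 values shown sits. Beyond what these two values show, nothing orders compound 1 and compound 2 against each other.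

Compound 3 `CNC(=O)NC[C@H]1O[C@@H](n2cnc3c(N)ncnc32)[C@H](OC(=O)c2ccccc2)[C@@H]1OC(=O)c1ccccc1` differs from compound 2 by hydrogen in place of phenylcarbamoyl on a nitrogen on an aromatic ring. Going by the values given here, no measured pair carries this change, so the expectation rests only on compound 2 sitting at the limit and compound 1 being weak in this assay. The step from compound 2 to compound 3 is expected to be small, a number no higher from compound 2 to compound 3 (the limit leaves the size open), with no direction that would exceed the usual scatter. Compound 3 is therefore expected to give 200 ug/mL in this assay, within 90 ug/mL to 450 ug/mL, and most likely to be reported again only as a limit rather than a number.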

Compound 3, half-maximal inhibitory concentration: 40 ug/mL
Compound 3: middle estimate off by 5.0-fold (0.70 log units), on the high side, outside the stated range (below it).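

In this assay, going by these compounds alone, with the benzoate esters held fixed, hydrogen in place of phenylcarbamoyl gives an at least 5.0-fold lower number from compound 2 to compound 3 (0.69 log units; beyond the scatter), the first measured change at this nitrogen on an aromatic ring. The phenylcarbamoyl group is therefore not required for activity in this pair, and its removal goes with stronger inhibition rather than weaker. On these data alone, the true size of the step remains unknown, as the value for compound 2 is a limit and not a number: the limit of > 200 ug/mL in this assay, at which 1 of the 3 values shown sits.

As far as these compounds go, it remains open whether this result reflects the phenylcarbamoyl group specifically or any substituent on this nitrogen, and an acetyl or methyl group on the amino nitrogen would help separate those two readings. This single pair also leaves open whether the same step holds with silyl ethers or free hydroxyl groups on the sugar, since both compounds in the pair carry benzoate esters.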